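The compounds below may be only part of what the source reports. "The series", "measured", "known", "first", "only" and "open" are said of these compounds alone.

Compound 1 `CC1(C)[C@H]2CC[C@]1(C)N(Cc1cn(-c3ccc(C#N)cc3)nn1)C(=O)C2` is the point of departure. In a functional assay on HepG2 cells (Homo sapiens) for inhibition, read by MTT assay, with a stated time of 24 h (a higher number here means a weaker inhibitor, a lower number a stronger inhibitor), compound 1 gives 50 nM, the second highest of the three numbers. Compound 3 `CC1(C)[C@H]2CC[C@]1(C)N(Cc1cn(-c3cccc(C#N)c3)nn1)C(=O)C2` gives 40 nM, and compound 2 `CC1(C)[C@H]2CC[C@]1(C)N(Cc1cn(-c3ccccc3C#N)nn1)C(=O)C2` gives 180 nM. The measured steps, a 1.3-fold lower number from compound 1 to compound 3 (0.10 log units; within the scatter), a 3.6-fold higher number from compound 1 to compound 2 (0.56 log units; beyond the scatter) and a 4.5-fold lower number from compound 2 to compound 3 (0.65 log units; beyond the scatter), all concern where the cyano group sits on the ring, not its exchange for another group. Compound 4 `CC1(C)[C@H]2CC[C@]1(C)N(Cc1cn(-c3ccc(O)cc3)nn1)C(=O)C2` differs from compound 1 by hydroxy in place of cyano on an aromatic carbon. Among the compounds with values here, no measured step bears on this exchange directly; the modest steps seen for the cyano group only suggest that changes on this ring matter at a modest level. A modest step toward a weaker inhibitor is therefore expected, a 2.2-fold higher number from compound 1 to compound 4 (0.34 log units; beyond the scatter). Compound 4 is estimated at 110 nM, within a range from 30 nM to 400 nM.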

Compound 4, half-maximal inhibitory concentration: 80 nM
Compound 4: the middle estimate sits 1.4-fold (0.14 log units) above what was measured; the range from low to high includes it.
By their numbers in this assay, from the lowest: compounds 3, 1 and 4 (each within the scatter of the next); then compound 2.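

In this assay, within the data shown here, the first exchange of the group itself, rather than a shift of the nitrile around the ring, leaves little trace (a 1.6-fold higher number from compound 1 to compound 4 (0.20 log units; within the scatter)), and compound 4 also stays within the scatter of the 3-cyanophenyl compound (a 2.0-fold higher number from compound 3 to compound 4 (0.30 log units; within the scatter)). Among the compounds shown, a nitrile is therefore not required for a number in this range, and only the 2-cyanophenyl compound stands apart (a 2.3-fold lower number from compound 2 to compound 4 (0.35 log units; beyond the scatter)). Nothing available explains this result.

As far as these compounds go, what an amine or a carboxylic acid would give in place of hydroxy remains open. So does the effect of hydroxy at the ring places that the nitrile occupies in compound 2 and compound 3.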